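The source may hold more compounds than are shown below. What is called first, only, known or untested is meant among the compounds shown, and "the series" means these compounds.

Measured compounds:
compound 1 `CNc1nc(N2CCC(N)CC2)c2sc(-c3ccc(C(F)(F)F)cc3)cc2n1` — 17 ug/mL
compound 2 `CNc1nc(NC2CCOCC2)c2sc(-c3ccc(C(F)(F)F)cc3)cc2n1` — < 5 ug/mL
compound 3 `Nc1nc(NC2CCOCC2)c2sc(-c3ccc(C(F)(F)F)cc3)cc2n1` — < 5 ug/mL

In a physicochemical assay for solubility, in phosphate buffer, at pH 6.5 (a lower number here means a less soluble compound, a higher number a more soluble compound), compound 1 gives 17 ug/mL. For compound 2 the result in this assay is a limit of the assay, < 5 ug/mL. For compound 3 the result in this assay is likewise a limit, < 5 ug/mL. Two of the three values therefore rest on (the limit of < 5 ug/mL in this assay, at which 2 of the 3 values shown sit), and the step that the two limits leave unreadable from compound 2 to compound 3 cannot be read for that reason.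

Compound 1 differs from compound 2 by 4-aminopiperidin-1-yl in place of (oxan-4-yl)amino on an aromatic carbon, and this change gave an at least 3.4-fold higher number from compound 2 to compound 1 (0.53 log units; beyond the scatter). Compound 4 `Nc1nc(N2CCC(N)CC2)c2sc(-c3ccc(C(F)(F)F)cc3)cc2n1` has not been measured. It differs from compound 3 by 4-aminopiperidin-1-yl in place of (oxan-4-yl)amino on an aromatic carbon; the cores of compound 3 and compound 2 differ by hydrogen in place of methyl on a nitrogen on an aromatic ring, so the change into compound 4 is the same kind of change as that into compound 1, not the same: around the place it is meta to an amino group (1 heavy atom) rather than meta to a methylamino group (2 heavy atoms).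

Compound 4 is expected to show an at least 3.0-fold higher number from compound 3 to compound 4 (0.47 log units; beyond the scatter) in this assay, a step of about the size seen from compound 2 to compound 1, an at least 3.4-fold higher number from compound 2 to compound 1 (0.53 log units; beyond the scatter), since compound 3 and compound 2 both sit at the same limit. Compound 4 is estimated at 15 ug/mL, with a range from 5 ug/mL to 45 ug/mL.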

Compound 4, solubility: 134 ug/mL
Compound 4: middle estimate off by 8.9-fold (0.95 log units), on the low side; the measured number lies above the stated range.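

In this assay, 4-aminopiperidin-1-yl in place of (oxan-4-yl)amino gives an at least 3.4-fold higher number from compound 2 to compound 1 (0.53 log units; beyond the scatter) on the core carrying the methylamino group and an at least 26-fold higher number from compound 3 to compound 4 (1.42 log units; beyond the scatter) on the core carrying the amino group, so the direction of the change carries across these two cores. The size does not carry as a fixed amount: the two 4-aminopiperidin-1-yl compounds differ only by hydrogen in place of methyl on a nitrogen on an aromatic ring and show a 7.9-fold higher number from compound 1 to compound 4 (0.90 log units; beyond the scatter), so the result on one core did not set the value reached on the other. The gap between the two steps of this change cannot be read, and neither can the step between the two (oxan-4-yl)amino compounds, because the values of compound 2 and compound 3 are both limits: the limit of < 5 ug/mL in this assay, at which 2 of the 4 values shown sit.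

The compounds shown leave open whether the step follows the free amine of 4-aminopiperidin-1-yl or the piperidine ring attached through its nitrogen, which plain piperidin-1-yl or (piperidin-4-yl)amino would separate. They also leave open whether the trend from methylamino to amino extends to a longer chain such as ethylamino, and whether the change carries over when a nitrile stands in place of trifluoromethyl.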